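This account rests on a few compounds, and the source may have more. Where it says the series, first, only, none or still open, it means among the compounds named here.

Measured compounds:
compound 1, `Cc1ccc2c(=O)cc(/C=C/[S+](C)[O-])oc2c1`: 2000 nM
compound 2, `CC(C)CC(=O)Oc1ccc2oc(/C=C/[S+](C)[O-])cc(=O)c2c1`: 2300 nM
compound 3, `Cc1cccc2oc(/C=C/[S+](C)[O-])cc(=O)c12`: 1300 nM

The three measured compounds share a common core and differ only in the substituent carried on it. In a functional assay on A549 cells (Homo sapiens) for cytotoxicity, with a stated time of 48 h (a lower number here means a stronger inhibitor, a higher number a weaker inhibitor), compound 2 gives 2300 nM, the highest of the three numbers, but its gaps to compound 1 at 2000 nM and to compound 3 at 1300 nM both fall within the usual scatter, so the three cannot be ranked against one another. Among the measured compounds shown here, no pair of measured compounds differs in a single place, so no step between them is available to guide the next change.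

Compound 4, `CC(C)Oc1ccc2oc(/C=C/[S+](C)[O-])cc(=O)c2c1`, is not yet measured. It differs from compound 2 in one place: isopropyl in place of isobutylcarbonyl on an oxygen on an aromatic ring. With the three measured numbers sitting so close together despite quite different substituents at the same kind of position, there is nothing in this set to suggest that this exchange should move the number in either direction beyond the scatter. Compound 4 is therefore expected to land near compound 2, with the step from compound 2 to compound 4 estimated at a 1.2-fold lower number from compound 2 to compound 4 (0.06 log units; within the scatter). The estimate for compound 4 in this assay is 2000 nM, with a range of 800 nM to 5000 nM.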

Compound 4, half-maximal inhibitory concentration: 1500 nM
Estimate against measurement, compound 4: 1.3-fold (0.12 log units) above; the range from low to high includes it.
By their numbers in this assay, from the lowest: compounds 3, 4, 1 and 2 (each within the scatter of the next).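

In this assay, among the compounds shown here, isopropyl in place of isobutylcarbonyl on this oxygen gives the only single-place comparison so far: a 1.5-fold lower number from compound 2 to compound 4 (0.19 log units; within the scatter). At this position, then, the number does not respond readably to losing the carbonyl and going from the larger to the smaller group, so neither feature of the isobutylcarbonyl is shown to matter here. No measurement bears on why this exchange leaves the number within the scatter.

The compounds shown leave open whether a group of another kind on this oxygen, such as a chain ending in an amine or a carboxylic acid, would move the number beyond the scatter. A free hydroxyl or a longer alkyl chain in the same place also remains untested among these compounds.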